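Methyl Added to an Aromatic Carbon in Two Pairs

The source may hold more compounds than are shown below. What is called first, only, known or untested is meant among the compounds shown, and "the series" means these compounds.

Measured so far: compound 1 `O=c1c(-c2nn[nH]n2)c[nH]c2c(F)cccc12` gives 10 mg/kg. Compound 2 `Cc1cccc2cc(C(=O)O)cnc12` reaches only a limit of the assay, > 25 mg/kg. Compound 3 `Cc1cc(F)c2[nH]cc(-c3nn[nH]n3)c(=O)c2c1` also reaches only a limit of the assay, > 10 mg/kg.

Within the data shown here, in a functional assay on the whole organism (strain Sprague-Dawley) for inhibition, with Rattus norvegicus as the target (a higher number here means that more compound is needed for the effect, a lower number that less compound is needed), compound 1 is the one measured compound with a number. The step of a number no lower from compound 1 to compound 3 (the limit leaves the size open) cannot be sized; it rests on (the limit of > 10 mg/kg in this assay, at which 1 of the 3 values shown sits). The change made there is methyl in place of hydrogen on an aromatic carbon. Compound 4 `Cc1ccc2cc(C(=O)O)cnc2c1C` differs from compound 2 by the same kind of change, (methyl in place of hydrogen on an aromatic carbon). Around the place the two pairs differ: in compound 3 the methyl stands meta to a fluoro group, in compound 4 ortho to a methyl group. The difference between the cores of compound 1 and compound 2 is not broken down here. Because compound 2 sits at the limit of > 25 mg/kg in this assay, at which 1 of the 3 values shown sits, the expected step is a step that the limit leaves unreadable from compound 2 to compound 4, which cannot be set beside the earlier one in size. Compound 4 is expected to give 40 mg/kg, between 20 mg/kg and 100 mg/kg, most probably again as a limit.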

Compound 4, minimum effective dose: 50 mg/kg
Estimate against measurement, compound 4: 1.3-fold (0.10 log units) below; low and high end bracket the measured number.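

No step from compound 2 to compound 4 can be read, because the figure for compound 2 is only a limit: the limit of > 25 mg/kg in this assay, at which 1 of the 4 values shown sits.

The compounds shown leave open how large a change methyl in place of hydrogen on an aromatic carbon brings in this assay, both from compound 1 to compound 3 and from compound 2 to compound 4.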